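Propyl for Isopropyl, Tested on a Second Core

This account rests on a few compounds, and the source may have more. Where it says the series, first, only, none or still open, it means among the compounds named here.

Of the compounds shown here, three have so far been measured in a functional assay on A549 cells (Homo sapiens) for antiproliferative activity, read by MTT assay, with a stated time of 72 h; a higher number here means a weaker inhibitor, a lower number a stronger inhibitor. Compound 1, `CC(C)/C=C/C(=O)Nc1cc2c(N3CCc4ccccc43)ncnc2cc1O[C@@H]1CCOC1`, gives 8520 nM. Compound 2, `CCC/C=C/C(=O)Nc1cc2c(N3CCc4ccccc43)ncnc2cc1O[C@@H]1CCOC1`, gives 9110 nM. The step between them is a 1.1-fold higher number from compound 1 to compound 2 (0.03 log units; within the scatter), and the change that produces it is propyl in place of isopropyl on a double-bonded chain carbon bound to a double-bonded chain carbon. This assay therefore does not separate the two.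

Compound 3, `COc1cc2ncnc(N3CCCc4ccccc43)c2cc1NC(=O)/C=C/C(C)C`, gives 3450 nM, the lowest of the three numbers, and its gaps to compound 1 and to compound 2 are both beyond the scatter. The difference between the core of compound 3 and the core of compound 1 is not broken down here.

Compound 4, `CCC/C=C/C(=O)Nc1cc2c(N3CCCc4ccccc43)ncnc2cc1OC`, has not yet been measured in this assay. It differs from compound 3 as propyl in place of isopropyl on a double-bonded chain carbon bound to a double-bonded chain carbon. The place of this change reads the same, word for word, as in the change from compound 1 to compound 2, so it is the same change carried onto the core of compound 3. Given that the earlier step was a 1.1-fold higher number from compound 1 to compound 2 (0.03 log units; within the scatter), the expected step here is a 1.1-fold higher number from compound 3 to compound 4 (0.04 log units; within the scatter). Compound 4 is accordingly estimated at 3800 nM, with a range from 2000 nM to 7500 nM. The expectation rests on a single precedent, and the two cores differ in ways not counted here, so the range is kept wide.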

Compound 4, half-maximal inhibitory concentration: 1800 nM
Estimate against measurement, compound 4: 2.1-fold (0.32 log units) above; the measured number lies below the stated range.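

In this assay, propyl in place of isopropyl on a double-bonded chain carbon bound to a double-bonded chain carbon gives a 1.9-fold lower number from compound 3 to compound 4 (0.28 log units; within the scatter), so on this second core the assay again does not separate the two chains. Set beside the earlier step, the result gives no sign that the core alters what this change does: the same change on two cores in this assay, a 1.1-fold higher number (0.03 log units; within the scatter) from compound 1 to compound 2 and a 1.9-fold lower number (0.28 log units; within the scatter) from compound 3 to compound 4, 2.0-fold (0.31 log units) apart, within the scatter of two such steps. This does not show that the change is without effect on every core in the series, nor that the two steps are truly equal, since the evidence is a single pair on each of two cores and a real difference smaller than the scatter would go unseen.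

The compounds shown leave open whether the indifference holds only between these two branched and straight chains of the same size, or whether a longer chain, a cyclopropyl ring or an amine carried in the same place would also leave the number unmoved. They also leave open which of the several differences between the core of compound 1 and the core of compound 3 matters in this assay, as those cores differ in more than one place.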